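Swapping the amide-side ring from pyrimidinyl to methylphenyl

The source may hold more compounds than are shown below. What is called first, only, known or untested is meant among the compounds shown, and "the series" means these compounds.

Measured so far:
compound 1, `O=C(CN1CCN(c2ccccn2)CC1)Nc1cccnc1`, 25800 nM
compound 2, `Cc1cccc(NC(=O)CN2CCN(c3ccc(Cl)cn3)CC2)c1`, 7780 nM
compound 3, `O=C(CN1CCN(c2ccccn2)CC1)Nc1cncnc1`, "not active" (no number reported)

All three share one core: a piperazine carrying a pyridine on one nitrogen and an amide-linked aromatic ring on the other. In an assay on cells for antagonist activity at D(4) dopamine receptor (Homo sapiens), read by luminescence and beta-arrestin recruitment, with a stated time of 90 min (on this read-out higher numbers stand for weaker inhibition and lower numbers for stronger inhibition), compound 1 gives 25800 nM, and compound 2 gives 7780 nM. In this assay, going by the values given here, compound 3 is reported as "not active" (no number reported), so no number can be placed beside it; it stands as the one member of the set without a measurable inhibition.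

The next compound, compound 4, `Cc1cccc(NC(=O)CN2CCN(c3ccccn3)CC2)c1`, differs from compound 3 in a single place: 3-methylphenyl in place of pyrimidin-5-yl on an amide-type nitrogen. Among the compounds with values here, no measured pair shows exactly this exchange, so the size of the step cannot be read from existing data. The expectation rests on the neighbours: compound 1 with a pyridinyl ring on the amide gives 25800 nM, and compound 2 with the same methylphenyl ring on a chlorinated core gives 7780 nM. Compound 4 is therefore expected to regain a measurable, weak inhibition, estimated at 18000 nM, within a range of 5000 nM to 70000 nM.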

Compound 4, half-maximal inhibitory concentration: 313 nM
Beside the measured number, compound 4's estimate is 58-fold (1.76 log units) above it; the measured number lies below the stated range.
By their numbers in this assay, from the lowest: compound 4; then compound 2; then compound 1.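

At the amide-type nitrogen, 3-methylphenyl in place of pyridin-3-yl gives an 82-fold lower number from compound 1 to compound 4 (1.92 log units; beyond the scatter) in this assay, showing that this one ring exchange can shift the number strongly; the step from compound 3 cannot be read, since compound 3 has no number. With 3-methylphenyl kept, hydrogen in place of chloro on an aromatic carbon gives a 25-fold lower number from compound 2 to compound 4 (1.40 log units; beyond the scatter), so compound 2 did not show how much inhibition this ring can carry on the unchlorinated core. Nothing available explains either step.

Whether the methyl group itself contributes remains open, as a plain phenyl ring is not among these compounds. Nor do they show how a methoxy group or an amine on this ring would compare with 3-methylphenyl.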